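Ester in place of acid on the amide nitrogen

The compounds below may be only part of what the source reports. "The series", "measured", "known", "first", "only" and "open" are said of these compounds alone.

Measured so far:
compound 1 `CCCCOC(=O)c1cccc(NC(=O)c2cccc(-c3cc(C(=O)Nc4ccncc4F)ccc3CN)c2)c1` gives 27 nM in an assay on cells for inhibition of Rho-associated protein kinase 2 (Homo sapiens), read by radiometric assay and 33P incorporation, in the presence of a further agent that is not named here; on this read-out lower numbers stand for stronger inhibition and higher numbers for weaker inhibition;
compound 2 `NCc1ccc(C(=O)Nc2ccncc2F)cc1-c1cccc(C(=O)Nc2ccc(CC(=O)O)cc2)c1` gives 1.8 nM in this assay.

Compound 2 holds the lowest of the two numbers in this assay; compound 1 sits well above it, a gap that lies beyond the usual scatter. Compound 3 `CC(C)OC(=O)c1cccc(NC(=O)c2cccc(-c3cc(C(=O)Nc4ccncc4F)ccc3CN)c2)c1` has not yet been measured. It differs from compound 2 by 3-(isopropoxycarbonyl)phenyl in place of 4-(carboxymethyl)phenyl on an amide-type nitrogen. Going by the values given here, no pair of measured compounds differs in exactly one place, so no measured step can be carried over directly. Of the two measured compounds, compound 1 is the one whose structure stands closer to compound 3; what the two values show is that compound 1 gives 27 nM. On that basis the step of a 12-fold higher number from compound 2 to compound 3 (1.09 log units; beyond the scatter) is expected to run towards weaker inhibition and to lie beyond the scatter. Compound 3 is therefore estimated at 22 nM in this assay, with a likely range from 8 nM to 60 nM.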

Compound 3, half-maximal inhibitory concentration: 7 nM
The estimate for compound 3 lay 3.1-fold (0.50 log units) above the measured number; measured number outside the range, below it.
By their numbers in this assay, from the lowest: compound 2; then compound 3; then compound 1.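

In this assay, the alkyl group on the ester oxygen proves to matter on its own: isopropyl in place of butyl on an oxygen next to a carbonyl group gives a 3.9-fold lower number from compound 1 to compound 3 (0.59 log units; beyond the scatter). The swap of 4-(carboxymethyl)phenyl for 3-(isopropoxycarbonyl)phenyl on an amide-type nitrogen now has a measured size, a 3.9-fold higher number from compound 2 to compound 3 (0.59 log units; beyond the scatter), a modest step that is smaller than the gap between compound 1 and compound 2 suggested. Nothing available here accounts for either step.

The second step replaces the whole group, so the share of the ester and the share of its place on the ring cannot be told apart. On these data alone, how a carboxylic acid in place of the isopropyl ester, or a shorter methyl or ethyl ester, would compare remains open.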